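One group swapped on a carbonyl carbon

This account rests on a few compounds, and the source may have more. Where it says the series, first, only, none or still open, it means among the compounds named here.

- compound 1 `CCN(CC)CCNC(=O)c1ccc(C(CC)(CC)c2ccc(OCCC(O)(CC)CC)c(C)c2)n1CC`: 2290 nM
- compound 2 `CCn1c(C(=O)NCC#N)ccc1C(CC)(CC)c1ccc(OCCC(O)(CC)CC)c(C)c1`: > 50000 nM (a limit)
- compound 3 `CCOC(=O)CN(C)C(=O)c1ccc(C(CC)(CC)c2ccc(OCCC(O)(CC)CC)c(C)c2)n1CC`: 1990 nM

In an ADME assay on L02 cells (Homo sapiens) for antiproliferative activity, read by MTT assay, with a stated time of 48 h (on this read-out higher numbers stand for weaker inhibition and lower numbers for stronger inhibition), compound 3 gives 1990 nM and sits level with compound 1, since a 1.2-fold lower number from compound 1 to compound 3 (0.06 log units; within the scatter) stays within the scatter. For compound 2 the value > 50000 nM is a limit of this assay and not a number. The two large steps are an at least 21-fold higher number from compound 1 to compound 2 (1.33 log units; beyond the scatter) and an at least 25-fold lower number from compound 2 to compound 3 (1.40 log units; beyond the scatter), and both involve compound 2.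

Compound 4 `CCn1c(C(=O)NC(CO)CCO)ccc1C(CC)(CC)c1ccc(OCCC(O)(CC)CC)c(C)c1` keeps the shared core of compound 3 and alters only the group on the carbonyl carbon, where the change is a group of 7 heavy atoms (4 carbon, 1 nitrogen, 2 oxygen; no ring) in place of a group of 8 heavy atoms (5 carbon, 1 nitrogen, 2 oxygen; no ring), on a carbonyl carbon in full. All three measured steps alter the group at this same carbonyl carbon, so all of them bear on the new change, yet they do not agree in size. Because a 1.2-fold lower number from compound 1 to compound 3 (0.06 log units; within the scatter) stayed within the scatter while an at least 25-fold lower number from compound 2 to compound 3 (1.40 log units; beyond the scatter) was large, a change here may do little or a great deal, and three compounds cannot settle which. A rise of moderate size is the expectation that sits between these outcomes. For compound 4 the expected step is a 5.0-fold higher number from compound 3 to compound 4 (0.70 log units; beyond the scatter) in this assay, toward a higher number. Compound 4 is estimated at 10000 nM, with an expected range of 2000 nM to 50000 nM.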

Compound 4, half-maximal inhibitory concentration: 3040 nM
Estimate against measurement, compound 4: 3.3-fold (0.52 log units) above; low and high end bracket the measured number.
By their numbers in this assay, from the lowest: compounds 3, 1 and 4 (each within the scatter of the next). At a limit, above all of these: compound 2.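

With compound 4, the group on the carbonyl carbon has now been changed twice without leaving the scatter in this assay: there is a 1.5-fold higher number from compound 3 to compound 4 (0.18 log units; within the scatter), and on the amide-type nitrogen there is a 1.3-fold higher number from compound 1 to compound 4 (0.12 log units; within the scatter), even though the group that enters carries hydrogen-bond donors and ((ethoxycarbonyl)methyl)(methyl)amino carries none. The large step seen earlier therefore no longer looks like a general feature of this position, and the new comparison with cyanomethyl on the amide-type nitrogen points the same way, with an at least 16-fold lower number from compound 2 to compound 4 (1.21 log units; beyond the scatter). Among the compounds shown, compound 2 alone goes against the flat pattern, and its value is a limit and not a number: the limit of > 50000 nM in this assay, at which 1 of the 4 values shown sits.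

Going by these compounds, what remains open is whether the nitrile or the short chain of cyanomethyl sets compound 2 apart, a question that a 2-cyanoethyl group or a plain ethyl group on the same nitrogen would address. A carboxylic acid or a ring amine at the end of this chain would show whether the flat pattern holds beyond the groups shown here.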